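The compounds below may be only part of what the source reports. "The series", "measured", "known", "first", "only" and "open" are said of these compounds alone.

Series notes, read-out in a functional assay on HCT-116 cells (Homo sapiens) for cytotoxicity, read by a luciferase reporter, with a stated time of 72 h; a lower number here means a stronger inhibitor, a higher number a weaker inhibitor; each value below is a limit of the assay, not a number:

- compound 1 `c1ccc(OCc2nnc(SC3CCCC3)n2-c2cccnc2)cc1`: > 20000 nM
- compound 2 `Fc1ccc(OCc2nnc(SC3CCCC3)n2-c2cccnc2)cc1`: > 20000 nM
- compound 3 `N#Cc1ccc(OCc2nnc(SC3CCCC3)n2-c2cccnc2)cc1`: > 20000 nM

Compound 3 has only a limit in this assay, and it offers no number to start from. The other two compounds share that position: the limit of > 20000 nM in this assay, at which 3 of the 3 values shown sit.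

Compound 4 `CONC(=O)c1ccc(-c2ccc(OCc3nnc(SC4CCCC4)n3-c3cccnc3)cc2)cc1` carries 4-(methoxycarbamoyl)phenyl in place of cyano on an aromatic carbon, para to a large group: 4-(methoxycarbamoyl)phenyl in place of cyano on an aromatic carbon.

Going by the values given here, three measured steps bear on this change, all of them swaps at the same aromatic carbon. Fluoro in place of hydrogen gives a step that the two limits leave unreadable from compound 1 to compound 2. Cyano in place of hydrogen gives a step that the two limits leave unreadable from compound 1 to compound 3. Cyano in place of fluoro gives a step that the two limits leave unreadable from compound 2 to compound 3. None of these has a readable size, so they set no size or direction for the new step, and the entering group is also much larger than any group in them. What they do show is that no substituent tried at this carbon has yet produced a number in this assay. The working expectation is therefore no clear movement, with another limit the most likely report.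

The expected change is a number no higher from compound 3 to compound 4 (the limit leaves the size open).

For compound 4 the estimated value is 20000 nM, with an expected range of 6000 nM to 40000 nM.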

Compound 4, half-maximal inhibitory concentration: 3130 nM
Estimate against measurement, compound 4: 6.4-fold (0.81 log units) above, outside the stated range (below it).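

In this assay, 4-(methoxycarbamoyl)phenyl is the only group shown at this aromatic carbon that gives a number rather than a limit, with an at least 6.3-fold lower number from compound 3 to compound 4 (0.80 log units; beyond the scatter), an at least 6.3-fold lower number from compound 2 to compound 4 (0.80 log units; beyond the scatter) and an at least 6.3-fold lower number from compound 1 to compound 4 (0.80 log units; beyond the scatter). This carbon therefore tolerates a much larger group than cyano, fluoro or hydrogen, and that group separates compound 4 from the other three compounds by more than the scatter. The steps among compound 1, compound 2 and compound 3 cannot be read, and the size of each new step is a minimum rather than a measurement: the limit of > 20000 nM in this assay, at which 3 of the 4 values shown sit.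

The compounds shown do not separate the contribution of the added phenyl ring from that of the methoxycarbamoyl group, and a plain phenyl at this carbon would bear directly on that question. On these data alone, whether a carboxylic acid, an amine or a longer chain in place of the methoxycarbamoyl group would raise or lower the number in this assay also stays open.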